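A few compounds are considered here, and "the series" means these few. Any claim that something is new, unique, unknown or untested is made for them only; others in the source may bear on it.

Working notes on the series. In a functional assay on SGC-7901 cells (Homo sapiens) for antiproliferative activity, read by MTT assay, with a stated time of 24 h (a higher number here means a weaker inhibitor, a lower number a stronger inhibitor), compound 1 (`O=C(NNc1ccccc1F)c1ccccc1NS(=O)(=O)c1cnc(O)nc1O`) gives > 20000 nM as a limit of the assay and not a number. Compound 2 (`O=C(NNC(=O)c1ccccc1NS(=O)(=O)c1cnc(O)nc1O)c1ccccc1F`) gives > 20000 nM as a limit too. Compound 2 therefore has no numerical position, and both values sit at one limit (the limit of > 20000 nM in this assay, at which 2 of the 2 values shown sit).

The next compound is compound 3 (`O=C(NNC(=O)c1ccccc1NS(=O)(=O)c1cnc(O)nc1O)c1ccc(F)cc1`), with 4-fluorophenyl in place of 2-fluorophenyl on a carbonyl carbon. The two have the same atoms, joined differently. Within the data shown here, the only measured step is a step that the two limits leave unreadable from compound 1 to compound 2 and it has no readable size. That step changes a group on an amine nitrogen, so it bears only loosely on this change. Among the measured compounds shown here, no measured pair tests 4-fluorophenyl against 2-fluorophenyl. With no measured size to carry over, no step beyond the scatter is expected in this assay and no direction is favoured. The expected step is a number no higher from compound 2 to compound 3 (the limit leaves the size open) and it is only a working figure. Compound 3 is most likely to return a limit as well. As a value, compound 3 is estimated at 20000 nM with an expected range of 8000 nM to 50000 nM in this read-out.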

Compound 3, half-maximal inhibitory concentration: > 20000 nM
Compound 3 ended at the assay's limit; the forecaster's own chance of this, stated with the estimate: 75%; the middle value lies on the limit itself.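

In this assay compound 3 gives > 20000 nM as a limit of the assay and not a number. Among these compounds, the steps among compound 1, compound 2 and compound 3 cannot be read, so no new step comes from them. The compounds shown leave open how 4-fluorophenyl and 2-fluorophenyl on a carbonyl carbon compare, since all values sit at one limit: the limit of > 20000 nM in this assay, at which 3 of the 3 values shown sit.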